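A phenylsulfanyl group added to compound 1

The compounds below may be only part of what the source reports. "The series", "measured", "known", "first", "only" and "open" are said of these compounds alone.

Three compounds have been measured in a functional assay on HeLa cells (Homo sapiens) for cytotoxicity; a lower number here means a stronger inhibitor, a higher number a weaker inhibitor:
compound 1 (`CC1=CCC[C@H]2[C@](C)(CC3=CC(=O)C=CC3=O)[C@@H](C)CC[C@]12C`), 26800 nM
compound 2 (`CC1=CCC[C@H]2[C@](C)(CC3=CC(=O)C(SC(C)C)=CC3=O)[C@@H](C)CC[C@]12C`), 67000 nM
compound 3 (`CC1=CCC[C@H]2[C@](C)(CC3=CC(=O)C(Sc4ccccc4)=CC3=O)[C@@H](C)CC[C@]12C`), 45000 nM

Compound 1 has the lowest of these three numbers, but its lead is small on both sides, and only the gap to compound 2 lies beyond the scatter. Compound 4 (`CC1=CCC[C@H]2[C@](C)(CC3=CC(=O)C=C(Sc4ccccc4)C3=O)[C@@H](C)CC[C@]12C`) has not yet been measured. It differs from compound 1 by phenylsulfanyl in place of hydrogen on a double-bonded ring carbon, two ring bonds from the ring atom that bears a large group.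

The closest evidence is compound 3, which also carries phenylsulfanyl in place of hydrogen on a double-bonded ring carbon, and that change gave a 1.7-fold higher number from compound 1 to compound 3 (0.23 log units; within the scatter). Compound 2, with isopropylsulfanyl, gave a 2.5-fold higher number from compound 1 to compound 2 (0.40 log units; beyond the scatter). On these two steps, a modest rise at most is expected in this assay. The expected step is a 1.5-fold higher number from compound 1 to compound 4 (0.17 log units; within the scatter) and no more. For compound 4 the estimated value is 40000 nM, with an expected range from 18000 nM to 90000 nM.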

Compound 4, half-maximal inhibitory concentration: 54800 nM
The estimate for compound 4 lay 1.4-fold (0.14 log units) below the measured number; the measured number falls inside the stated range.
By their numbers in this assay, from the lowest: compounds 1, 3, 4 and 2 (each within the scatter of the next, the first and the last beyond it).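

In this assay, phenylsulfanyl at this place, two ring bonds from the ring atom that bears a large group, gives a 2.0-fold higher number from compound 1 to compound 4 (0.31 log units; beyond the scatter). This is a modest step, but it shows that the group is tolerated here without a large loss, as it was at the ring carbon carrying it in compound 3. Moving the group between these two ring carbons separates little: compound 3 gives 45000 nM and compound 4 gives 54800 nM, values within the scatter of each other.

From the compounds shown here alone, whether an amine or a carboxylic acid at this place would give a number different from that of compound 1 remains open. No measurement shown here explains the step from hydrogen to phenylsulfanyl.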